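The source may hold more compounds than are shown below. What is called first, only, known or untested is meant among the compounds shown, and "the series" means these compounds.

Compound 1 `CC(c1ccc(-c2ccccc2)c(F)c1)c1n[nH]c(=S)n1N` carries an open, unfused heterocycle, whereas compound 2 `CC(c1ccc(-c2ccccc2)c(F)c1)c1nnc2n1N=C(c1ccc(Cl)cc1)CS2` and compound 3 `CC(C)Cc1ccc(C(C)c2nnc3n2N=C(c2ccc(Br)cc2)CS3)cc1` share a fused core. In a functional assay on SNU-475 cells (Homo sapiens) for inhibition, read by sulforhodamine B assay, with a stated time of 72 h (on this read-out higher numbers stand for weaker inhibition and lower numbers for stronger inhibition), compound 1 gives "not active" (no number reported), compound 2 gives 3800 nM and compound 3 gives 10100 nM. Compound 2 therefore holds the lower of the two reported numbers, and its gap to compound 3 lies beyond the usual scatter. Compound 4 `CC(c1ccc(-c2ccccc2)c(F)c1)c1nnc2n1N=C(c1ccc([N+](=O)[O-])cc1)CS2` has not yet been measured in this assay. It differs from compound 2 in one place: nitro in place of chloro on an aromatic carbon. Within the data shown here, no measured pair shows this exchange, so its size is open. A step of a 1.2-fold lower number from compound 2 to compound 4 (0.07 log units; within the scatter) is expected, which is no change beyond the scatter. Compound 4 is estimated at 3200 nM, between 1000 nM and 10000 nM.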

Compound 4, half-maximal inhibitory concentration: 7100 nM
Compound 4: middle estimate off by 2.2-fold (0.35 log units), on the low side; the range from low to high includes it.
By their numbers in this assay, from the lowest: compounds 2, 4 and 3 (each within the scatter of the next, the first and the last beyond it).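

In this assay, among these compounds, nitro in place of chloro, para to a large group, gives a 1.9-fold higher number from compound 2 to compound 4 (0.27 log units; within the scatter) as the first reading of this exchange. Compound 2 and compound 4 therefore cannot be told apart here, even though nitro brings more heavy atoms and two hydrogen-bond acceptors to the aromatic ring. Nothing measured here offers an explanation for this result.

Going by these compounds, it remains open whether an amine or a carboxylic acid at this place would also leave the number within the scatter. On these data alone, it is equally open whether the exchange would read the same alongside the other side of compound 3.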